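Amidoxime for benzoyl on the chromene core: expected potency

The source may report more compounds than this note shows. Statements on the series, on what has been measured and on what is new or still open speak of the compounds shown alone.

Measured so far:
compound 1 `CC1(C)C=C(n2ccccc2=O)c2cc(C(=O)c3ccccc3)ccc2O1` — 6.21
compound 2 `CC1(C)C=C(n2ccccc2=O)c2cc(C(=O)c3ccccc3[N+](=O)[O-])ccc2O1` — 5.64

In a functional assay (trachea) with Rattus norvegicus as the target (on this read-out lower numbers stand for lower potency and higher numbers for higher potency (the scale is a negative logarithm)), compound 1 gives 6.21, the higher of the two numbers in hand; compound 2, carrying nitro in place of hydrogen on an aromatic carbon, gives 5.64. Going by the values given here, the one measured step, a number 0.57 log units lower from compound 1 to compound 2 (beyond the scatter), is a modest loss beyond the scatter.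

Compound 3 `CC1(C)C=C(n2ccccc2=O)c2cc(C(=N)NO)ccc2O1` is to be measured in this assay. Relative to compound 1 the change is a group of 4 heavy atoms (1 carbon, 2 nitrogen, 1 oxygen; no ring) in place of a group of 8 heavy atoms (7 carbon, 1 oxygen; one six-membered aromatic ring of carbon only), on an aromatic carbon. Among the compounds with values here, no measured step removes the benzoyl itself; the step from compound 1 to compound 2 only alters that group, so it bears on the new step indirectly, suggesting that change at this position is tolerated but not neutral. A loss larger than that one is therefore expected, with wide uncertainty. The estimated step is a number 0.81 log units lower from compound 1 to compound 3 (beyond the scatter). Compound 3 is estimated at 5.4, within 4.6 to 6.2.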

Compound 3, logarithm of the reciprocal of the active concentration, log(1/C): 5.51
The estimate for compound 3 lay 0.11 log units below the measured number; measured number inside the range.
By their numbers in this assay, from the lowest: compounds 3 and 2 (each within the scatter of the next); then compound 1.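

The benzoyl group is not needed for activity at this aromatic carbon: in this assay the amidoxime that replaces it, with no ring, gives a modest loss, a number 0.70 log units lower from compound 1 to compound 3 (beyond the scatter), so potency survives removal of the whole group and not only the alteration seen with the nitro group. Compound 3 at 5.51 and compound 2 at 5.64 lie within the scatter of each other, so in this pair of numbers, the ring-free replacement and the nitro-bearing benzoyl cannot be told apart. No measurement in hand accounts for the size of this step.

Still open, going by these compounds, is which part of the change carries the step, the departure of the aromatic ring or the arrival of the amidoxime. A nitrile or a carboxylic acid on the same aromatic carbon would bear on this.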